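The source may hold more compounds than are shown below. What is called first, only, known or untested is meant among the compounds shown, and "the series" means these compounds.

Measured so far in a functional assay on HL-60 cells (Homo sapiens) for antiproliferative activity, read by MTT assay, with a stated time of 72 h; a higher number here means a weaker inhibitor, a lower number a stronger inhibitor

- Compound 1 `NC1=NC2(CCOCC2)N(OCCCOc2ccccc2)C(N)=N1` gives 2460 nM
- Compound 2 `NC1=NC2(CCOCC2)N(OCCCOc2cccc(Cl)c2Cl)C(N)=N1` gives 440 nM

Compound 2 has the lower number of the two, which makes it the stronger inhibitor, and its gap to compound 1 lies beyond the scatter. Compound 3 `NC1=NC2(CCOCC2)N(OCCCOc2ccc(F)cc2)C(N)=N1` keeps the shared core and alters one group, as counted here: 4-fluorophenyl in place of 2,3-dichlorophenyl on an oxygen on a saturated carbon. In words, it carries 4-fluorophenyl in place of 2,3-dichlorophenyl on an oxygen on a saturated carbon.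

For the measured compounds named here, only one measured step bears on this change, and it is modest: a 5.6-fold lower number from compound 1 to compound 2 (0.75 log units; beyond the scatter). Going by the values given here, no compound with fluorine has been measured, so the estimate is uncertain. Losing the 2,3-dichlorophenyl group should undo much of that step and raise the number in this assay beyond the scatter. The expected change is a 3.4-fold higher number from compound 2 to compound 3 (0.53 log units; beyond the scatter). For compound 3 the estimated value is 1500 nM, with an expected range from 600 nM to 3500 nM.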

Compound 3, half-maximal inhibitory concentration: 2380 nM
Estimate against measurement, compound 3: 1.6-fold (0.20 log units) below, within the range that was stated.
By their numbers in this assay, from the lowest: compound 2; then compounds 3 and 1 (each within the scatter of the next).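

In this assay, the gain seen with the 2,3-dichlorophenyl group does not carry over to every substituted phenyl ring: moving to the 4-fluorophenyl group gives it up entirely (a 5.4-fold higher number from compound 2 to compound 3 (0.73 log units; beyond the scatter)). Adding the single fluoro to the plain phenyl ring changes nothing that can be told apart from scatter (a 1.0-fold lower number from compound 1 to compound 3 (0.01 log units; within the scatter)), so compounds 1 and 3 stand level and, of these three, only compound 2 stands apart. Nothing measured here explains why the two chlorine atoms matter and the fluorine does not.

Still open, as far as these compounds go, is whether one chlorine would be enough, as in a 2-chlorophenyl or 3-chlorophenyl group, or whether both are needed. From the compounds shown here alone, it is also open how a 4-chlorophenyl group, or a longer chain carrying the 2,3-dichlorophenyl ring, would behave.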